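The source may report more compounds than this note shows. Statements on the series, on what has been measured and on what is new or still open speak of the compounds shown alone.

Measured so far:
compound 1, `COc1ccc(-c2cnc(NC(=O)CCc3ccccc3)n2C)cc1`: > 100000 nM
compound 2, `COc1ccc(-c2ccnc(NC(=O)c3ccc(F)cc3)c2)cc1`: > 100000 nM

In a toxicity assay on THP-1 cells (Homo sapiens) for inhibition (on this read-out lower numbers stand for higher toxicity in this test and higher numbers for lower toxicity in this test), compound 1 gives only a limit, > 100000 nM. Compound 2 likewise gives a limit, > 100000 nM. Among the compounds with values here, both readings sit at the limit of > 100000 nM in this assay, at which 2 of the 2 values shown sit, so no step between measured compounds can be drawn. Compound 3, `COc1ccc(-c2cnc(NC(C)=O)n2C)cc1`, is not yet measured. It differs from compound 1 by hydrogen in place of benzyl on a saturated chain carbon bound to a carbonyl carbon. With both measured readings at the limit, the step for compound 3 in this assay is expected to be none beyond the scatter, as a step that the limit leaves unreadable from compound 1 to compound 3. Compound 3 is estimated at 150000 nM, between 50000 nM and 500000 nM, most probably again reported as a limit.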

Compound 3, half-maximal cytotoxic concentration: > 100000 nM
Compound 3: only a limit was reported; the forecaster's own chance of this, stated with the estimate: 85%; the middle value lies beyond the limit too.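

No step can be read from compound 1 to compound 3 in this assay, as both readings are limits: the limit of > 100000 nM in this assay, at which 3 of the 3 values shown sit.

The compounds shown leave open which change to the shared core, if any, would bring a reading inside the measurable range.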